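This account rests on a few compounds, and the source may have more. Where it says the series, first, only, none or still open, it means among the compounds named here.

In a functional assay on MCF7 cells (Homo sapiens) for inhibition, read by MTT assay (a higher number here means a weaker inhibitor, a lower number a stronger inhibitor), compound 1 `COc1cc2ncnc(Nc3ccc(NC(=O)c4ccc(F)cc4)cc3)c2cc1OC` gives 27000 nM and compound 2 `COc1cc2ncnc(Nc3ccc(NC(=O)c4ccc(Br)cc4)cc3)c2cc1OC` gives 43000 nM. Exchanging fluoro for bromo on the aromatic carbon gives a 1.6-fold higher number from compound 1 to compound 2 (0.20 log units; within the scatter), so these two compounds cannot be told apart. Compound 3 `COc1cc2ncnc(Nc3ccc(NC(=O)c4cccc(C(F)(F)F)c4)cc3)c2cc1OC` reads > 100000 nM, which is a limit and not a number. Its place on the scale is the limit of > 100000 nM in this assay, at which 1 of the 3 values shown sits.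

Compound 4 `COc1cc2ncnc(Nc3ccc(NC(=O)c4cc(F)ccc4Br)cc3)c2cc1OC` carries 2-bromo-5-fluorophenyl in place of 3-(trifluoromethyl)phenyl on a carbonyl carbon. The two measured steps that end at compound 3 bear most directly on this change, as each brings in the same 3-(trifluoromethyl)phenyl group. These are an at least 3.7-fold higher number from compound 1 to compound 3 (0.56 log units; beyond the scatter) and an at least 2.3-fold higher number from compound 2 to compound 3 (0.36 log units; beyond the scatter). Both sizes are only lower bounds, and neither compound 1 nor compound 2 holds the 2-bromo-5-fluorophenyl group, so the comparison is only partial.

Removing the 3-(trifluoromethyl)phenyl group is nevertheless expected to move the number down by a modest step, towards the range of the two halogen-bearing compounds. The expected change is an at least 2.2-fold lower number from compound 3 to compound 4 (0.34 log units; beyond the scatter). For compound 4 the estimated value is 45000 nM, with an expected range of 18000 nM to 100000 nM.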

Compound 4, half-maximal inhibitory concentration: 26000 nM
The estimate for compound 4 lay 1.7-fold (0.24 log units) above the measured number; low and high end bracket the measured number.
By their numbers in this assay, from the lowest: compounds 4, 1 and 2 (each within the scatter of the next). At a limit, above all of these: compound 3.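

The new compound shows that a ring carrying two halogens on the carbonyl carbon reads no differently from a ring carrying one: in this assay there is a 1.7-fold lower number from compound 2 to compound 4 (0.22 log units; within the scatter) and a 1.0-fold lower number from compound 1 to compound 4 (0.02 log units; within the scatter), so these three compounds cannot be told apart. Exchanging 3-(trifluoromethyl)phenyl for 2-bromo-5-fluorophenyl gives an at least 3.8-fold lower number from compound 3 to compound 4 (0.58 log units; beyond the scatter), which is beyond the scatter and leaves the 3-(trifluoromethyl)phenyl compound as the only one of the four set apart from the others. The size of that step is only a bound, as compound 3 reads a limit and not a number: the limit of > 100000 nM in this assay, at which 1 of the 4 values shown sits.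

All four compounds carry a phenyl ring with fluoro, bromo or trifluoromethyl on the carbonyl carbon, so the compounds shown leave open how an unsubstituted phenyl, or a ring bearing an amine or a carboxylic acid, would read in this assay. They also leave open what the bromo and the fluoro of 2-bromo-5-fluorophenyl each contribute, as neither appears alone at those places on the ring.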